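A few compounds are considered here, and "the series" means these few. Any claim that something is new, unique, unknown or untested is made for them only; others in the source may bear on it.

Measured so far:
compound 1 `CSc1nc2c(C)nsc2[nH]1` — 13000 nM
compound 2 `Cc1nsc2c1ncn2[C@H]1C[C@H](O)[C@@H](CO)O1` — > 100000 nM

In a functional assay on L1210 cells (Mus musculus) for antiproliferative activity (on this read-out lower numbers stand for stronger inhibition and higher numbers for weaker inhibition), compound 1 gives 13000 nM. Compound 2 gives no number in this assay, only the limit > 100000 nM; this is the limit of > 100000 nM in this assay, at which 1 of the 2 values shown sits. Compound 2 therefore stands at the weak end of what has been measured, with no value to anchor it. Compound 1 carries a methylsulfanyl group and gives a number; compound 2 carries a hydrogen in its place. For the measured compounds named here, no pair of measured compounds differs in one place, so no measured step is available for the size of a substitution of this kind.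

Compound 3 `Cc1nsc2c1nc(SCc1ccccc1)n2[C@H]1C[C@H](O)[C@@H](CO)O1` differs from compound 2 by benzylsulfanyl in place of hydrogen on an aromatic carbon. Compound 3 is expected to move from the limit of compound 2 toward a measurable number, a step of an at least 2.5-fold lower number from compound 2 to compound 3 (0.39 log units; beyond the scatter) in this assay, with the size uncertain since compound 2 has only a limit. Compound 3 is estimated at 40000 nM, within 8000 nM to 200000 nM.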

Compound 3, half-maximal inhibitory concentration: > 100000 nM
Compound 3: no number, only a limit; the forecaster's own chance of this, stated with the estimate: 45%; middle value at least 2.5-fold (0.39 log units) from the limit.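

No step from compound 2 to compound 3 can be read in this assay, since each gives only a limit: the limit of > 100000 nM in this assay, at which 2 of the 3 values shown sit.

The compounds shown leave open what change, if any, benzylsulfanyl in place of hydrogen on an aromatic carbon brings to antiproliferative activity.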